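The source may hold more compounds than are shown below. What is called first, only, known or untested is meant among the compounds shown, and "the series" means these compounds.

Compound 1 `C[C@@H]1O[C@H](C2CCCCC2)C([Si](C)(C)C)=C(Cl)[C@H]1C`: 42000 nM
Compound 2 `C[C@@H]1O[C@H](CCC=C(Br)Br)C([Si](C)(C)C)=C(Cl)[C@H]1C`: 25000 nM

In a functional assay on WiDr cells (Homo sapiens) for antiproliferative activity (a higher number here means a weaker inhibitor of growth, a lower number a stronger inhibitor of growth), compound 2 gives 25000 nM, and compound 1 gives 42000 nM. Among the measured compounds shown here, the single measured step, a 1.7-fold lower number from compound 1 to compound 2 (0.23 log units; within the scatter), lies within the scatter, so compound 2 cannot be told apart from compound 1. Compound 3 `C#CCC[C@H]1O[C@@H](C)[C@H](C)C(Cl)=C1[Si](C)(C)C` differs from compound 2 by ethynyl in place of 2,2-dibromoethenyl on a saturated chain carbon, two bonds along the chain from a saturated ring carbon. For the measured compounds named here, no measured step touches this part of the chain, and the one step known swaps the whole side group, so it gives only weak guidance. The step from compound 2 to compound 3 is therefore expected to stay within the scatter, a 1.1-fold higher number from compound 2 to compound 3 (0.05 log units; within the scatter). Compound 3 is estimated at 28000 nM, between 10000 nM and 80000 nM.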

Compound 3, concentration for 50% growth inhibition: 24000 nM
Beside the measured number, compound 3's estimate is 1.2-fold (0.07 log units) above it; the measured number falls inside the stated range.
By their numbers in this assay, from the lowest: compounds 3, 2 and 1 (each within the scatter of the next).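

In this assay, ethynyl in place of 2,2-dibromoethenyl on a saturated chain carbon, two bonds along the chain from a saturated ring carbon, gives a 1.0-fold lower number from compound 2 to compound 3 (0.02 log units; within the scatter), so losing both bromine atoms and trading the double bond for a triple bond leaves no readable change. But-3-yn-1-yl in place of cyclohexyl gives a 1.8-fold lower number from compound 1 to compound 3 (0.24 log units; within the scatter), so all three side groups remain indistinguishable here. Nothing further is available to explain this result. As far as these compounds go, whether an amine, a carboxylic acid or a longer chain at this position would move the number beyond the scatter remains open.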